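From compound 2 to compound 3: exchanging the aromatic ring

The source may hold more compounds than are shown below. What is called first, only, known or untested is meant among the compounds shown, and "the series" means these compounds.

Compound 1 `C[C@@H](Oc1cc2oc(=O)n(CCC(=O)O)c2cc1Cl)c1cccnn1` gives 0.83
Compound 2 `O=C(O)CCn1c(=O)oc2cc(OCc3ccccn3)c(Cl)cc21` gives 1.32

Compound 2 stands at 1.32 in a physicochemical assay for lipophilicity, read by HPLC, at pH 7.4 (on this read-out lower numbers stand for lower lipophilicity and higher numbers for higher lipophilicity), and is the higher of the two. One change leads from compound 2 to compound 3 `C[C@@H](Oc1cc2oc(=O)n(CCC(=O)O)c2cc1Cl)c1ncco1`, which is not yet measured: a group of 7 heavy atoms (5 carbon, 1 nitrogen, 1 oxygen; one five-membered aromatic ring with 2 hetero atoms) in place of a group of 7 heavy atoms (6 carbon, 1 nitrogen; one six-membered aromatic ring with 1 hetero atom), on an oxygen on an aromatic ring. Going by the values given here, the only measured step that bears on this is a number 0.49 log units higher from compound 1 to compound 2 (beyond the scatter), modest in size, and it starts from a six-membered aromatic ring with 2 hetero atoms. The entering ring also has 2 hetero atoms but is five-membered, so a smaller fall is expected, none beyond the scatter. The expected move is a number 0.22 log units lower from compound 2 to compound 3 (within the scatter) in this assay. For compound 3 the estimated value is 1.1, with a range from 0.8 to 1.4.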

Compound 3, distribution coefficient: 1.11
Compound 3: middle estimate off by 0.01 log units, on the low side; the measured number falls inside the stated range.
By their numbers in this assay, from the lowest: compounds 1, 3 and 2 (each within the scatter of the next, the first and the last beyond it).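

In this assay, the oxygen on the aromatic ring accepts a five-membered aromatic ring group in place of (pyridin-2-yl)methyl, giving a number 0.21 log units lower from compound 2 to compound 3 (within the scatter). On the same saturated chain carbon, 1,3-oxazol-2-yl in place of pyridazin-3-yl gives a number 0.28 log units higher from compound 1 to compound 3 (within the scatter). Compound 3 thus lies within the scatter of both neighbours, even though those two differ beyond it.

Nothing available explains these numbers. Still open, going by these compounds, is how this assay would read with a plain phenyl ring on that saturated chain carbon, and whether an amine on the ring would shift it.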